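Notes on a cytotoxicity series and a carboxy analogue

The source may report more compounds than this note shows. Statements on the series, on what has been measured and on what is new or still open speak of the compounds shown alone.

compound 1 `CN1CCN(C(=O)c2cc3c(Nc4ccc(OC(F)(F)F)cc4)ncnc3s2)CC1`: 2690 nM
compound 2 `NC(=O)CCn1ccc2c(Nc3ccc(OC(F)(F)F)cc3)ncnc21`: > 10000 nM, a limit of the assay
compound 3 `Nc1cccc(-c2cc(Nc3ccc(OC(F)(F)F)cc3)ncn2)c1`: > 10000 nM, a limit of the assay

In an ADME assay on BaF3 cells (Mus musculus) for cytotoxicity (a higher number here means that more compound is needed for the effect, a lower number that less compound is needed), compound 1 gives 2690 nM. For compound 2 the value > 10000 nM is a limit of the assay and not a number. For compound 3 the value > 10000 nM is likewise a limit of the assay. For the measured compounds named here, compound 1 thus stands as the only number in this set, the other two values being limits, as summed up in the limit of > 10000 nM in this assay, at which 2 of the 3 values shown sit.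

Compound 4 `O=C(O)c1cc2c(Nc3ccc(OC(F)(F)F)cc3)ncnc2s1` has not yet been measured in this assay. It differs from compound 1 in one place: hydroxy in place of 4-methylpiperazin-1-yl on a carbonyl carbon. Going by the values given here, no step between measured compounds is known against which this change could be set, so the expectation rests on the standing of compound 1 and on the limits of compound 2 and compound 3. An upward step in this assay is expected, of about a 3.0-fold higher number from compound 1 to compound 4 (0.47 log units; beyond the scatter), with a real chance that the assay reports only a limit. Compound 4 is estimated at 8000 nM, between 3000 nM and 30000 nM.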

Compound 4, half-maximal effective concentration: > 10000 nM
Compound 4 ended at the assay's limit; the forecaster's own chance of this, stated with the estimate: 55%; middle value at least 1.2-fold (0.09 log units) away from the limit.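

In this assay, for the compounds shown here, hydroxy in place of 4-methylpiperazin-1-yl on a carbonyl carbon gives the first step in this set that can be read: an at least 3.7-fold higher number from compound 1 to compound 4 (0.57 log units; beyond the scatter). For compound 4 the value > 10000 nM is a limit of the assay and not a number, so the step marks only the smallest possible change. The change thus shows that the read-out at this place responds to the group on the carbonyl carbon, while compound 1 remains the only compound with a number: the limit of > 10000 nM in this assay, at which 3 of the 4 values shown sit.

As far as these compounds go, it remains open whether a methyl ester, a primary amide or an amide of piperazine without the methyl group would stay near compound 1 or reach the limit. From the compounds shown here alone, the full size of the step also stays open.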